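This account rests on a few compounds, and the source may have more. Where it says the series, first, only, none or still open, it means among the compounds named here.

In a functional assay on HCT-116 cells (Homo sapiens) for antiproliferative activity, read by MTT assay, with a stated time of 24 h (a higher number here means a weaker inhibitor, a lower number a stronger inhibitor), compound 1 (`COc1ccc(-c2noc(C3CCCN3)n2)cc1OC1CCCC1`) gives 185000 nM and compound 2 (`COc1ccc(-c2noc(-c3ccc(F)cc3)n2)cc1OC1CCCC1`) gives 210000 nM so the two stand level within the scatter. Compound 3 (`COc1ccc(-c2noc(-c3ccc(Cl)cc3)n2)cc1OC1CCCC1`) carries chloro in place of fluoro on an aromatic carbon. Among the compounds with values here, no measured step covers this swap directly. Within the data shown here, the only guide is a 1.1-fold higher number from compound 1 to compound 2 (0.06 log units; within the scatter) for 4-fluorophenyl in place of pyrrolidin-2-yl, so no step beyond the scatter is expected in this assay here. Compound 3 is estimated at 180000 nM with a range from 80000 nM to 350000 nM as the expected spread. This estimate means a 1.2-fold lower number from compound 2 to compound 3 (0.07 log units; within the scatter) as the expected step.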

Compound 3, half-maximal inhibitory concentration: > 1000000 nM
Compound 3: no number, only a limit; the forecaster's own chance of this, stated with the estimate: 10%; middle value at least 5.5-fold (0.74 log units) away from the limit.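

In this assay the reading for compound 3 is a limit and not a number: the limit of > 1000000 nM in this assay, at which 1 of the 3 values shown sits. Even so, exchanging a single halogen on the aromatic carbon gives an at least 4.7-fold higher number from compound 2 to compound 3 (0.67 log units; beyond the scatter), so this place responds to a one-atom change, which the earlier pair did not reveal. Replacing pyrrolidin-2-yl with 4-chlorophenyl gives an at least 5.4-fold higher number from compound 1 to compound 3 (0.73 log units; beyond the scatter), whereas 4-fluorophenyl stood level with pyrrolidin-2-yl within the scatter. As far as these compounds go, the full size of both steps stays open behind the limit. Also open, from the compounds shown here alone, is where bromo or an amine at this same place would fall.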